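Swapping the furanoyl aryl on a trimethoxyphenyl triazolothiadiazine core

The source may hold more compounds than are shown below. What is called first, only, known or untested is meant among the compounds shown, and "the series" means these compounds.

Measured compounds in a functional assay on MCF7 cells (Homo sapiens) for cytotoxicity, read by MTT assay, with a stated time of 48 h; on this read-out lower numbers stand for stronger inhibition and higher numbers for weaker inhibition:
compound 1 `COc1cc(-c2nnc3n2NC(c2ccco2)C(C(=O)c2ccco2)S3)cc(OC)c1OC`, a limit of the assay: > 100000 nM
compound 2 `COc1cc(-c2nnc3n2NC(c2ccco2)C(C(=O)c2cccc(Br)c2)S3)cc(OC)c1OC`: 91800 nM
compound 3 `COc1cc(-c2nnc3n2NC(c2ccco2)C(C(=O)c2ccc(C)cc2)S3)cc(OC)c1OC`, a limit of the assay: > 100000 nM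

Compound 1 stands at the limit, (the limit of > 100000 nM in this assay, at which 2 of the 3 values shown sit). Compound 4 `COc1cccc(C(=O)C2Sc3nnc(-c4cc(OC)c(OC)c(OC)c4)n3NC2c2ccco2)c1` carries 3-methoxyphenyl in place of furan-2-yl on a carbonyl carbon. The related replacements of furan-2-yl by other aryls gave an at least 1.0-fold lower number from compound 1 to compound 2 (0.03 log units; that floor lies within the scatter) and a step that the two limits leave unreadable from compound 1 to compound 3, neither a readable change. No step beyond the scatter is therefore expected in this assay, and the result may again be only a limit. Compound 4 is expected to give 100000 nM, in the range 60000 nM to 200000 nM. The expected step is a number no higher from compound 1 to compound 4 (the limit leaves the size open).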

Compound 4, half-maximal inhibitory concentration: > 100000 nM
Compound 4: only a limit was reported; the forecaster's own chance of this, stated with the estimate: 60%; the middle value lies on the limit itself.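

Placing 3-methoxyphenyl on the carbonyl carbon adds a further aryl at this position without a readable value, and compound 2 remains the exception with a measured number: the limit of > 100000 nM in this assay, at which 3 of the 4 values shown sit. The steps from compound 1 and from compound 3 to compound 4 cannot be read, as both ends are limits. Methoxy in place of bromo gives an at least 1.0-fold higher number from compound 2 to compound 4 (0.03 log units; that floor lies within the scatter), so the two groups cannot be told apart here.

On these data alone, whether an amine or a carboxylic acid on this aryl ring would bring a value clearly within the range of this assay remains open.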